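From Pyridin-3-yl to Thiophen-2-yl on a Carbonyl Carbon

A few compounds are considered here, and "the series" means these few. Any claim that something is new, unique, unknown or untested is made for them only; others in the source may bear on it.

Of the compounds shown here, two have so far been measured in an ADME assay on HepG2 2.2.15 cells (Homo sapiens) for cytotoxicity, read by MTT assay; on this read-out higher numbers stand for lower toxicity in this test and lower numbers for higher toxicity in this test. There, compound 1 (`C=C1CC[C@@H]2[C@](C)(COC(=O)c3cc(=O)c4ccccc4o3)[C@H](O)CC[C@@]2(C)[C@@H]1/C=C/C1=CCOC1=O`) gives 171000 nM and compound 2 (`C=C1CC[C@@H]2[C@](C)(CO)[C@H](OC(=O)c3cccnc3)CC[C@@]2(C)[C@@H]1C/C=C1\C=COC1=O`) gives 337000 nM. These two numbers lie within the usual scatter of each other, so compound 2 cannot be told apart from compound 1 on this measure.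

Compound 3 (`C=C1CC[C@@H]2[C@](C)(CO)[C@H](OC(=O)c3cccs3)CC[C@@]2(C)[C@@H]1C/C=C1\C=COC1=O`) has not yet been measured. It differs from compound 2 in one place, with thiophen-2-yl in place of pyridin-3-yl on a carbonyl carbon. For the measured compounds named here, no pair of measured compounds shows what a single change of this kind does in this assay, so the forecast rests on little evidence. Starting from compound 2 at 337000 nM, the change swaps one aromatic ring with one hetero atom for another and brings no net charge, so only a small step is expected, leaning towards a lower number and hardly beyond the scatter. The estimated step is a 1.4-fold lower number from compound 2 to compound 3 (0.15 log units; within the scatter). For compound 3 the expected value is 240000 nM, with an estimated range from 100000 nM to 520000 nM.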

Compound 3, half-maximal cytotoxic concentration: 257000 nM
For compound 3 the middle estimate is 1.1-fold (0.03 log units) below the measured one, within the range that was stated.
By their numbers in this assay, from the lowest: compounds 1, 3 and 2 (each within the scatter of the next).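

In this assay, for the compounds shown here, the exchange of pyridin-3-yl for thiophen-2-yl on a carbonyl carbon gives a 1.3-fold lower number from compound 2 to compound 3 (0.12 log units; within the scatter), and this is the first comparison here between compounds that differ in one place only. At this position, therefore, a six-membered aromatic ring with nitrogen as its hetero atom and a five-membered aromatic ring with sulfur as its hetero atom cannot be told apart on this read-out, even though both the ring size and the hetero atom change. No supporting measurement is at hand to explain why the two rings read alike.

Going by these compounds, with only these two rings compared, it remains open whether a group of another kind on this carbonyl carbon, such as a simple amine, a carboxylic acid or a longer chain of carbon atoms, would produce a step beyond the scatter. Going by these compounds alone, it also remains open whether the same exchange would read the same way on a different core, since this one pair of compounds is the only evidence for it.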